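Chain Lengthening by One Carbon on Two Related Cores

The source may hold more compounds than are shown below. What is called first, only, known or untested is meant among the compounds shown, and "the series" means these compounds.

Compound 1 `N=C(N)c1ccc2oc(-c3cccc(OCCCCCOc4ccccc4)c3)cc2c1` and compound 2 `N=C(N)c1ccc2oc(-c3cccc(OCCCCCCOc4ccccc4)c3)cc2c1` share one core; in an ADME assay on L6 cells (Rattus norvegicus) for cytotoxicity, read by resazurin assay, with a stated time of 70 h (a higher number here means a weaker inhibitor, a lower number a stronger inhibitor), compound 1 gives 3000 nM and compound 2 gives 3100 nM. The change between them, (phenoxymethyl in place of phenoxy on a saturated chain carbon, five bonds along the chain from an oxygen on an aromatic ring), produced a 1.0-fold higher number from compound 1 to compound 2 (0.01 log units; within the scatter). Compound 3 `N=C(N)c1ccc2cc(-c3cccc(OCCCOc4ccccc4)c3)oc2c1` carries a core whose difference from the core of compound 1 is not broken down here; in this assay compound 3 gives 19800 nM, the highest of the three numbers. Compound 4 `N=C(N)c1ccc2cc(-c3cccc(OCCCCOc4ccccc4)c3)oc2c1` arises from compound 3 by the same kind of change, (phenoxymethyl in place of phenoxy on a saturated chain carbon, three bonds along the chain from an oxygen on an aromatic ring); around the place it differs in that the saturated chain carbon lies three bonds along the chain from an oxygen on an aromatic ring rather than five. Because the earlier step of a 1.0-fold higher number from compound 1 to compound 2 (0.01 log units; within the scatter) stayed within the scatter, the expected step here is a 1.1-fold lower number from compound 3 to compound 4 (0.04 log units; within the scatter), resting on that single precedent alone. Compound 4 is therefore estimated at 18000 nM, between 9000 nM and 36000 nM.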

Compound 4, half-maximal inhibitory concentration: 7600 nM
The estimate for compound 4 lay 2.4-fold (0.37 log units) above the measured number; the measured number lies below the stated range.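

In this assay, phenoxymethyl in place of phenoxy gave a 2.6-fold lower number from compound 3 to compound 4 (0.42 log units; beyond the scatter), so the change did not carry over unaltered from one core to the other: the same change on two cores in this assay, a 1.0-fold higher number (0.01 log units; within the scatter) from compound 1 to compound 2 and a 2.6-fold lower number (0.42 log units; beyond the scatter) from compound 3 to compound 4, 2.7-fold (0.43 log units) apart, beyond the scatter of two such steps

The two steps also differ in place, the saturated chain carbon lying three bonds along the chain from an oxygen on an aromatic ring in one pair and five in the other, so the effect of the core cannot be separated from that of chain length. With one pair on each core, the comparison shows no trend and gives no reason for the gap.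

The compounds shown leave open whether a longer chain on the core of compound 3 would behave as on the core of compound 1. They also leave open how an amine or a carboxylic acid in place of phenoxy would fare on either core.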